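The source may report more compounds than this note shows. Statements on the series, on what has been measured and on what is new or still open speak of the compounds shown alone.

Within the data shown here, in a physicochemical assay for solubility, read by HPLC, in phosphate buffer, measured as kinetic solubility, with a stated time of 24 h, at pH 7.4, tested at 200 uM (on this read-out higher numbers stand for higher solubility and lower numbers for lower solubility), compound 1 (`CCc1cccc(CC)c1NC(=O)c1ccn(-c2nc(Nc3ccc(N4CCC(N5CCN(C)CC5)CC4)cc3OC)nc3[nH]ccc23)c1`) reads 53000 nM and compound 3 (`CCc1cccc(CC)c1N1CCn2cc(-c3nc(Nc4ccc(N5CCN(CC(=O)N(C)C)CC5)cc4OC)nc4[nH]ccc34)cc2C1=O`) reads 1400 nM as the two outer numbers so far. Compound 2 (`CCc1cccc(CC)c1N1CCn2cc(-c3nc(Nc4ccc(N5CCC(N6CCN(C)CC6)CC5)cc4OC)nc4[nH]ccc34)cc2C1=O`) stands between them with 6000 nM and is clearly apart from both. Compound 4 (`CCc1cccc(CC)c1N1CCn2cc(-c3nc(Nc4ccc(N5CCC(C(=O)N6CC7(CN(C)C7)C6)CC5)cc4OC)nc4[nH]ccc34)cc2C1=O`) keeps everything in compound 2 except one group on a saturated ring carbon: a group of 10 heavy atoms (7 carbon, 2 nitrogen, 1 oxygen; 2 four-membered non-aromatic rings with 1 hetero atom each) in place of a group of 7 heavy atoms (5 carbon, 2 nitrogen; one six-membered non-aromatic ring with 2 hetero atoms), on a saturated ring carbon is the whole change. Among the measured compounds shown here, no measured pair shows this swap alone, so the size of the step can only be judged loosely. A small downward step is expected, and a 1.5-fold lower number from compound 2 to compound 4 (0.18 log units; within the scatter) is the estimated move, probably within the scatter. Compound 4 is estimated at 4000 nM with a range from 1200 nM to 15000 nM on this measure.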

Compound 4, solubility: 180000 nM
The estimate for compound 4 lay 45-fold (1.65 log units) below the measured number; measured number above the stated range.
By their numbers in this assay, from the lowest: compound 3; then compound 2; then compound 1; then compound 4.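

In this assay, the saturated ring carbon turns out to be a place where one swap can matter greatly: exchanging 4-methylpiperazin-1-yl for the group with two four-membered non-aromatic rings gives a 30-fold higher number from compound 2 to compound 4 (1.48 log units; beyond the scatter), a large step. Both groups count the same hydrogen-bond donors and acceptors, so those counts do not separate them. No measurement shown here accounts for the step. Going by these compounds, it remains open which part of the entering group carries the step, the carbonyl or the four-membered rings. A simple dimethylamino group or a carboxylic acid on the same carbon would help to separate these.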